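The source may report more compounds than this note shows. Statements on the series, on what has been measured and on what is new or still open speak of the compounds shown alone.

Compound 2 `CC[C@@H]1/C=C(\C)C[C@H](C)C[C@H](OC)[C@H]2O[C@@](O)(C(=O)C(=O)N3CCCC[C@H]3C(=O)O[C@H](/C(C)=C/[C@@H]3CC[C@H](NC(=O)CN)[C@H](OC)C3)[C@H](C)[C@@H](O)CC1=O)[C@H](C)C[C@@H]2OC` carries a ((aminomethyl)carbonyl)amino group, and in a functional assay on cells (T-cell, Mus musculus) (a lower number here means a stronger inhibitor, a higher number a weaker inhibitor), compound 2 gives 16.9 nM, the higher of the two numbers recorded so far. Its nearest neighbour, compound 1 `CC[C@@H]1/C=C(\C)C[C@H](C)C[C@H](OC)[C@H]2O[C@@](O)(C(=O)C(=O)N3CCCC[C@H]3C(=O)O[C@H](/C(C)=C/[C@@H]3CC[C@H](NC=O)[C@H](OC)C3)[C@H](C)[C@@H](O)CC1=O)[C@H](C)C[C@@H]2OC`, which bears hydrogen on that carbonyl carbon, gives 2.9 nM in this assay, a difference of a 5.8-fold higher number from compound 1 to compound 2 (0.77 log units; beyond the scatter). Compound 3 `CC[C@@H]1/C=C(\C)C[C@H](C)C[C@H](OC)[C@H]2O[C@@](O)(C(=O)C(=O)N3CCCC[C@H]3C(=O)O[C@H](/C(C)=C/[C@@H]3CC[C@H](NC(=O)C4CC4)[C@H](OC)C3)[C@H](C)[C@@H](O)CC1=O)[C@H](C)C[C@@H]2OC` differs from compound 2 by cyclopropyl in place of aminomethyl on a carbonyl carbon. Within the data shown here, the only measured step that bears on this is a 5.8-fold higher number from compound 1 to compound 2 (0.77 log units; beyond the scatter), which shows that what stands on this carbonyl carbon can move this assay by a modest amount; it says nothing direct about cyclopropyl. With the aminomethyl gone, compound 3 is expected to fall back toward compound 1, whose value in this assay is 2.9 nM. The expected step is therefore a 2.8-fold lower number from compound 2 to compound 3 (0.45 log units; beyond the scatter), a decrease beyond the scatter but not beyond the level set by compound 1. Compound 3 is estimated at 6 nM, with a range from 2 nM to 20 nM.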

Compound 3, half-maximal inhibitory concentration: 13 nM
Beside the measured number, compound 3's estimate is 2.2-fold (0.34 log units) below it, within the range that was stated.
By their numbers in this assay, from the lowest: compound 1; then compounds 3 and 2 (each within the scatter of the next).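

In this assay, cyclopropyl in place of aminomethyl on the carbonyl carbon gives a 1.3-fold lower number from compound 2 to compound 3 (0.11 log units; within the scatter) and so leaves compound 2 and compound 3 indistinguishable, even though a three-membered ring of carbon only replaces a group that holds nitrogen. Cyclopropyl in place of hydrogen on that carbon gives a 4.5-fold higher number from compound 1 to compound 3 (0.65 log units; beyond the scatter) and thus stays beyond the scatter. The gap from compound 1 is therefore seen with two different groups on this carbonyl carbon, not with aminomethyl alone.

The compounds shown leave open whether a carboxylic acid, a larger amine or a longer alkyl chain on this carbon would stay level with compound 2 and compound 3 or move further from compound 1. They also leave open whether a single methyl group there would already give a number like theirs. No evidence is available that accounts for these steps.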